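Taking the carbonyl group off compound 2

The source may hold more compounds than are shown below. What is called first, only, known or untested is meant among the compounds shown, and "the series" means these compounds.

Measured so far:
compound 1 `CCCn1c(-c2ccc(O)cc2)c(C)c2ccccc21`: 7100 nM
compound 2 `Cc1ncsc1C(=O)Oc1ccc(-c2[nH]c3ccccc3c2C)cc1`: > 20000 nM (a limit, not a number)
compound 3 `Cc1c(-c2ccc(O)c(O)c2)n(CCCOc2ccccc2)c2ccc(O)cc12`: 7100 nM

All three compounds were tested in a functional assay on MSTO-211H cells (Homo sapiens) for inhibition, read by trypan blue exclusion, with a stated time of 72 h; on this read-out higher numbers stand for weaker inhibition of growth and lower numbers for stronger inhibition of growth. Compound 1 gives 7100 nM, and compound 3 gives 7100 nM. The reading for compound 2 is > 20000 nM, which is a limit of the assay and not a number.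

The compound to follow here is compound 4 `Cc1c(-c2ccc(O)cc2)[nH]c2ccccc12`, which has not yet been measured. It differs from compound 2 in one place: hydrogen in place of (4-methyl-1,3-thiazol-5-yl)carbonyl on an oxygen on an aromatic ring. Put simply, hydrogen stands in place of (4-methyl-1,3-thiazol-5-yl)carbonyl on an oxygen on an aromatic ring.

Within the data shown here, no two measured compounds differ in only one place, so the size of this step can only be judged loosely. Compound 1 also has a hydrogen on an oxygen on an aromatic ring and gives 7100 nM. Compound 3 has such a hydrogen too and gives 7100 nM. On that basis, a modest move towards stronger inhibition of growth is expected in this assay, although compound 4 could still end up close to the limit. The expected change is an at least 2.0-fold lower number from compound 2 to compound 4 (0.30 log units; that floor lies within the scatter). For compound 4 the estimate is 10000 nM, with an expected range of 4500 nM to 20000 nM.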

Compound 4, concentration for 50% growth inhibition: > 20000 nM
Compound 4 was reported as a limit; the forecaster's own chance of this, stated with the estimate: 20%; middle value at least 2.0-fold (0.30 log units) away from the limit.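

In this assay compound 4 gives > 20000 nM as a limit of the assay and not a number. Freeing the oxygen on the aromatic ring by removing the (4-methyl-1,3-thiazol-5-yl)carbonyl therefore brings no measurable inhibition into view, and the step between the two compounds that carry this difference cannot be read because both stop at the same ceiling: the limit of > 20000 nM in this assay, at which 2 of the 4 values shown sit.

The readable news comes from a different place, the aromatic nitrogen, where hydrogen in place of propyl gives an at least 2.8-fold higher number from compound 1 to compound 4 (0.44 log units; beyond the scatter) in this assay, a step beyond the usual scatter, so within this one pair the propyl group goes with stronger inhibition of growth. As far as these compounds go, whether a butyl chain, or a chain ending in an amine, on that nitrogen would move the number further in the same direction stays open, and a single pair cannot show a trend. Also open is what a small acetyl group on the oxygen would do when the aromatic nitrogen carries propyl, since the only such change shown here ends at a limit.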